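The compounds below may be only part of what the source reports. "The series", "measured", "known", "first", "only" and "open" are said of these compounds alone.

Compound 2 `COc1cc(NC(C)CCCNC(=O)NNC(=O)NCCCO)c2ncccc2c1` gives 45% in a physicochemical assay for inhibition, read by spectrophotometry, tested at 100 uM (on this read-out lower numbers stand for less inhibition and higher numbers for more inhibition at the one concentration tested (going by the name of the read-out)), and stands lowest of the two measured numbers, beneath compound 1 `COc1cc(NC(C)CCCNC(=O)NN)c2ncccc2c1`, which gives 70% in this assay. Going by the values given here, the one measured step, a number 25 percentage points lower from compound 1 to compound 2 (beyond the scatter), is the only guide. Compound 3 `COc1cc(NC(C)CCCNC(=O)Nc2ccc(Cl)c(C(F)(F)F)c2)c2ncccc2c1` differs from compound 2 by 4-chloro-3-(trifluoromethyl)phenyl in place of ((3-hydroxypropyl)carbamoyl)amino on an amide-type nitrogen, which removes the group that the measured step had introduced, so a partial return toward compound 1 is expected, as a number 17 percentage points higher from compound 2 to compound 3 (beyond the scatter). Among the compounds with values here, the direct aryl replacement has no precedent here, so the range is wide. Compound 3 is estimated at 62%, between 38% and 86%.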

Compound 3, a percentage reported as inhibition, at one concentration (the size of the read-out at that concentration, not a potency): 61%
Compound 3: the middle estimate sits 1 percentage points above what was measured; the measured number falls inside the stated range.
By their numbers in this assay, from the lowest: compound 2; then compounds 3 and 1 (each within the scatter of the next).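

At this amide-type nitrogen, 4-chloro-3-(trifluoromethyl)phenyl restores much of the number lost with ((3-hydroxypropyl)carbamoyl)amino in this assay, with a number 16 percentage points higher from compound 2 to compound 3 (beyond the scatter). Against the amino group of compound 1, the same aryl group gives a number 9 percentage points lower from compound 1 to compound 3 (within the scatter), so this position accepts a group of 11 heavy atoms with no hydrogen-bond donors or acceptors and stays within the scatter of amino. No evidence accounts for either step.

On these data alone, whether the chlorine or the trifluoromethyl matters remains open, as an unsubstituted phenyl would be needed to tell. As far as these compounds go, how a carboxylic acid or a longer chain would read at this nitrogen also remains open.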